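A few compounds are considered here, and "the series" means these few. Any claim that something is new, unique, unknown or untested is made for them only; others in the source may bear on it.

Notes on the series. In a functional assay on CHO cells for agonist activity at Free fatty acid receptor 1 (Homo sapiens), read by FLIPR and calcium flux, tested at 100 nM (on this read-out lower numbers stand for a weaker effect and higher numbers for a stronger effect at the one concentration tested), compound 3 `Cc1nc(-c2cccc(Cl)c2)sc1COc1ccc2c(c1)OCC2CC(=O)O` gives 43% and stands highest of the three numbers. Compound 1 `Cc1nc(-c2cccs2)sc1COc1ccc2c(c1)OCC2CC(=O)O` gives 35.2% in this assay, and a number 7.8 percentage points higher from compound 1 to compound 3 (within the scatter). Compound 2 `Cc1nc(-c2cccc3ccccc23)sc1COc1ccc2c(c1)OCC2CC(=O)O` gives 8.53% in this assay, and a number 34.5 percentage points higher from compound 2 to compound 3 (beyond the scatter); likewise a number 26.7 percentage points lower from compound 1 to compound 2 (beyond the scatter). Compound 4 `Cc1nc(-c2ccc(Cl)cc2)sc1COc1ccc2c(c1)OCC2CC(=O)O` differs from compound 3 by 4-chlorophenyl in place of 3-chlorophenyl on an aromatic carbon. Among the measured compounds shown here, no measured step moves a chlorine between positions on the same ring; the measured steps only exchange whole aryl groups, and of these the two six-membered aryl compounds, compound 1 and compound 3, lie within the scatter of each other. The step in this assay is therefore expected to be none beyond the scatter, a number 3 percentage points lower from compound 3 to compound 4 (within the scatter). Compound 4 is estimated at 40%, within 20% to 60%.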

Compound 4, a percentage reported as activity, at one concentration (the size of the read-out at that concentration, not a potency): 53.4%
Beside the measured number, compound 4's estimate is 13.4 percentage points below it; low and high end bracket the measured number.
By their numbers in this assay, from the lowest: compound 2; then compounds 1 and 3 (each within the scatter of the next); then compound 4.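

In this assay, moving the chlorine within the same ring gives a step of its own, a number 10.4 percentage points higher from compound 3 to compound 4 (beyond the scatter), so at this position the place of the chlorine counts as well as the choice of aryl group. Compound 4 now stands clear of both other aryl variants, with a number 18.2 percentage points higher from compound 1 to compound 4 (beyond the scatter) and a number 44.9 percentage points higher from compound 2 to compound 4 (beyond the scatter). Nothing available explains why the 4-chlorophenyl group reads higher.

Open, from the compounds shown here alone, is how a 2-chlorophenyl group would read here. Also open, going by these compounds, is whether a 4-fluorophenyl or 4-methoxyphenyl group would match compound 4, which would show whether chlorine itself matters.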